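A few compounds are considered here, and "the series" means these few. Any claim that something is new, unique, unknown or untested is made for them only; others in the source may bear on it.

Measured so far in a functional assay on MCF7 cells (Homo sapiens) for inhibition, read by MTT assay, with a stated time of 48 h; a higher number here means a weaker inhibitor, a lower number a stronger inhibitor:
- compound 1 `CCOC(=O)C1=C(N/N=C(/C#N)C(=O)OCC)Nc2[nH]nc(C)c2C1c1ccc(N(C)C)cc1` gives 35600 nM 
- compound 2 `CCOC(=O)C1=C(N/N=C(/C(=O)Br)c2ccc(Br)cc2)Nc2[nH]nc(C)c2C1c1ccc(N(C)C)cc1` gives 61300 nM 
- compound 3 `CCOC(=O)C1=C(NN=C(C#N)C#N)Nc2[nH]nc(C)c2C1c1ccc(N(C)C)cc1` has no value yet

Compound 2 stands level with compound 1: a 1.7-fold higher number from compound 1 to compound 2 (0.24 log units; within the scatter) stays within the scatter, so these two values are not separated. The change to compound 3 is a group of 6 heavy atoms (3 carbon, 3 nitrogen; no ring) in place of a group of 12 heavy atoms (8 carbon, 1 nitrogen, 1 oxygen, 2 bromine; one six-membered aromatic ring of carbon only), on an amine nitrogen and it falls on the same amine nitrogen as that measured step. For the measured compounds named here, this single step is the only evidence available, and it exchanged a group with no ring for one with a ring without leaving the scatter. Compound 1 at 35600 nM also carries a group with no ring there. No step beyond the scatter is therefore expected in this assay for this change. The expected 1.5-fold lower number from compound 2 to compound 3 (0.19 log units; within the scatter) would remain within the scatter. Compound 3 is estimated at 40000 nM with an expected range of 12000 nM to 100000 nM for now.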

Compound 3, half-maximal inhibitory concentration: 12100 nM
The estimate for compound 3 lay 3.3-fold (0.52 log units) above the measured number; the range from low to high includes it.
By their numbers in this assay, from the lowest: compound 3; then compounds 1 and 2 (each within the scatter of the next).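

In this assay, this amine nitrogen, whose other neighbour is the double-bonded ring carbon, is not indifferent to the group it carries: the group with two nitriles gives a 5.1-fold lower number from compound 2 to compound 3 (0.70 log units; beyond the scatter) and also a 2.9-fold lower number from compound 1 to compound 3 (0.47 log units; beyond the scatter). Loss of the aromatic ring does not by itself account for this, since compound 1 also has no ring at this place yet stays within the scatter of compound 2. Nothing measured here gives a reason for either step.

Whether both nitriles are needed remains open, as the compounds shown do not separate the second nitrile from the first. A carboxylic acid or a primary amide in place of one nitrile, or a longer chain ending in a nitrile, would test how far the trend extends.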